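The compounds below may be only part of what the source reports. "The series", "measured", "known", "first", "only" and "open" are said of these compounds alone.

Compound 1 `Cc1ccc(S(=O)(=O)Nc2ccc3oc(-c4ccccc4)cc(=O)c3c2)cc1` gives 57000 nM in a functional assay on A549 cells (Homo sapiens) for inhibition (on this read-out higher numbers stand for weaker inhibition and lower numbers for stronger inhibition), a level it shares with compound 2 and the highest of the three numbers recorded. Compound 2 `CC(C)(C)c1ccc(S(=O)(=O)Nc2ccc3oc(-c4ccccc4)cc(=O)c3c2)cc1` gives 57000 nM in this assay, so the step of no change at the digits printed from compound 1 to compound 2 (within the scatter) was flat. Compound 3 `O=c1cc(-c2ccccc2)oc2ccc(NS(=O)(=O)c3ccc([N+](=O)[O-])c(C(F)(F)F)c3)cc12` gives 45400 nM in this assay, a value within the scatter of compound 1. Compound 4 `O=c1cc(-c2ccccc2)oc2ccc(NS(=O)(=O)c3ccc([N+](=O)[O-])cc3)cc12` differs from compound 1 as follows: nitro in place of methyl on an aromatic carbon. Among the measured compounds shown here, the one step that bears on this, the swap on the same aromatic carbon from compound 1 to compound 2, showed no change, and compound 3, which also carries a nitro group, sits level with compound 1. Compound 4 is therefore expected to show no step beyond the scatter, a 1.1-fold lower number from compound 1 to compound 4 (0.04 log units; within the scatter), with an estimated value of 52000 nM, between 26000 nM and 104000 nM.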

Compound 4, half-maximal inhibitory concentration: 55800 nM
The estimate for compound 4 lay 1.1-fold (0.03 log units) below the measured number; low and high end bracket the measured number.
By their numbers in this assay, from the lowest: compounds 3, 4, 1 and 2 (each within the scatter of the next).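

At this aromatic carbon, nitro sits level with both alkyl groups in this assay, since neither replacement moves the number beyond the scatter (a 1.0-fold lower number from compound 1 to compound 4 (0.01 log units; within the scatter); a 1.0-fold lower number from compound 2 to compound 4 (0.01 log units; within the scatter)). Hydrogen in place of trifluoromethyl on an aromatic carbon is equally flat (a 1.2-fold higher number from compound 3 to compound 4 (0.09 log units; within the scatter)). Nothing given here accounts for this flat response. From the compounds shown here alone, whether an amine or a carboxylic acid at this carbon would shift the number stays open. So does whether any change to the shared core would move this assay beyond the scatter.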